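Moving the Chlorine on the Benzyl Group of Compound 2

The source may report more compounds than this note shows. Statements on the series, on what has been measured and on what is new or still open speak of the compounds shown alone.

Among the measured compounds shown here, compound 2 `C/C(C#Cc1ccccc1)=N\N/C(N)=N/S(=O)(=O)c1cc(C)c(Cl)cc1SCc1cccc(Cl)c1` gives 155000 nM in an ADME assay on HaCaT cells (Homo sapiens) for cytotoxicity, read by MTT assay, with a stated time of 72 h (on this read-out lower numbers stand for stronger inhibition and higher numbers for weaker inhibition), the higher of the two numbers known, though within the scatter of compound 1. Compound 1 `C/C(C#Cc1ccccc1)=N\N/C(N)=N/S(=O)(=O)c1cc(C)c(Cl)cc1SCc1cccc(C(F)(F)F)c1` gives 105000 nM, and the step of a 1.5-fold higher number from compound 1 to compound 2 (0.17 log units; within the scatter) lies within the scatter. Compound 3 `C/C(C#Cc1ccccc1)=N\N/C(N)=N/S(=O)(=O)c1cc(C)c(Cl)cc1SCc1ccc(Cl)cc1` differs from compound 2 by 4-chlorophenyl in place of 3-chlorophenyl on a saturated chain carbon bound to a sulfur. For the measured compounds named here, no measured step shifts a chlorine around a ring; the single known step concerned a different group and stayed within the scatter, so nothing points to a change beyond it. Compound 3 is therefore expected at 150000 nM, between 75000 nM and 300000 nM, an estimated 1.0-fold lower number from compound 2 to compound 3 (0.01 log units; within the scatter).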

Compound 3, half-maximal inhibitory concentration: 16000 nM
Compound 3: middle estimate off by 9.4-fold (0.97 log units), on the high side; measured number below the stated range.
By their numbers in this assay, from the lowest: compound 3; then compounds 1 and 2 (each within the scatter of the next).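

In this assay, a 9.7-fold lower number from compound 2 to compound 3 (0.99 log units; beyond the scatter) follows from 4-chlorophenyl taking the place of 3-chlorophenyl, so where the chlorine sits on this group matters here, unlike the swap of chloro for trifluoromethyl, which stayed within the scatter. With 4-chlorophenyl in place of 3-(trifluoromethyl)phenyl, a 6.6-fold lower number from compound 1 to compound 3 (0.82 log units; beyond the scatter) points the same way. Nothing measured here explains this shift. The compounds shown leave open whether an amine or a carboxylic acid on this aromatic ring would keep the lower number. They also leave open what a longer chain at the carbon bound to the sulfur would do.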